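A few compounds are considered here, and "the series" means these few. Any claim that something is new, unique, unknown or untested is made for them only; others in the source may bear on it.

Measured so far in an ADME assay on cells (spleen, Mus musculus, strain C57BL/6) for inhibition, read by flow cytometry and propidium iodide staining, with a stated time of 24 h, at 37 degrees C; a higher number here means that more compound is needed for the effect, a lower number that less compound is needed
- compound 1 `Nc1ccc(-c2cn(CC(=O)NCc3ccccc3)nn2)cc1` gives 1240 uM
- compound 2 `Cc1ccc(-c2cn(CC(=O)NCc3ccccc3)nn2)cc1` gives "non-toxic" (no number reported)

Compound 2 has no single number in this assay, only the result "non-toxic" (no number reported). Compound 3 `O=C(Cn1cc(-c2ccc([N+](=O)[O-])cc2)nn1)NCc1ccccc1` is still unmeasured. The change nitro in place of methyl on an aromatic carbon is nitro in place of methyl on an aromatic carbon, para to a large group. Among the measured compounds shown here, compound 1 at 1240 uM is the only number available, so only a modest step is expected in this assay, towards a measurable value in that same high range, meaning a lower number than the result for compound 2 implies. For compound 3 the expected value is 800 uM, with an estimated range of 200 uM to 2500 uM.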

Compound 3, concentration for half-maximal effect: 800 uM
The estimate for compound 3 equals the measured number at the digits printed; the measured number falls inside the stated range.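

In this assay, replacing amino with nitro, para to a large group, gives a 1.6-fold lower number from compound 1 to compound 3 (0.19 log units; within the scatter), so the data do not separate these two groups at this position. The step from methyl cannot be read, as compound 2 carries only the result "non-toxic" and no number. Nothing measured here bears on the reason for this result.

Still open, on these data alone, is how a carboxylic acid or a longer chain would read at this position. Also open, as far as these compounds go, is whether changes elsewhere on the shared core move the number beyond the scatter.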